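The source may report more compounds than this note shows. Statements on the series, on what has been measured and on what is new or still open speak of the compounds shown alone.

Of the compounds shown here, two have so far been measured in a functional assay on Venous blood for antagonist activity at C-X-C chemokine receptor type 3 (Homo sapiens), read by flow cytometry, with a stated time of 30 min, in the presence of a further agent that is not named here; on this read-out higher numbers stand for weaker inhibition and lower numbers for stronger inhibition. Compound 1 `C[C@@H]1CN(c2sc(C(F)(F)F)nc2-c2nc3ccccc3[nH]2)CCN1C(=O)Cn1cnc2c1CCN(C)C2` gives 135 nM in this assay. Compound 2 `Cc1nc(C)n(CC(=O)N2CCN(c3sc(C(F)(F)F)nc3-c3nc4ccc(S(C)(=O)=O)cc4[nH]3)C[C@H]2C)n1` differs from compound 1 at several places. In this assay compound 2 gives 959 nM. Compound 1 thus shows the lower of the two numbers, and its gap to compound 2 lies beyond the usual scatter of repeated measurements.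

Compound 3 `C[C@@H]1CN(c2sc(C(F)(F)F)nc2-c2nc3ccccc3[nH]2)CCN1C(=O)CN1CCC(F)(F)CC1` has not yet been measured. It differs from compound 1 in one place: a group of 8 heavy atoms (5 carbon, 1 nitrogen, 2 fluorine; one six-membered non-aromatic ring with 1 hetero atom) in place of a group of 10 heavy atoms (7 carbon, 3 nitrogen; one five-membered aromatic ring with 2 hetero atoms, one six-membered non-aromatic ring with 1 hetero atom), on a saturated chain carbon bound to a carbonyl carbon. For the measured compounds named here, no measured pair shows what this change does, so its direction cannot be read from the numbers at hand. A modest weakening is expected, since the group that leaves is the larger one and carries more hydrogen-bond acceptors than the one that enters. The step is estimated at a 2.0-fold higher number from compound 1 to compound 3 (0.30 log units; within the scatter). Compound 3 is therefore expected to give about 270 nM in this assay, within a range of 90 nM to 800 nM.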

Compound 3, half-maximal inhibitory concentration: 2430 nM
Compound 3: middle estimate off by 9.0-fold (0.95 log units), on the low side; the whole stated range lies below it.
By their numbers in this assay, from the lowest: compound 1; then compound 2; then compound 3.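

The group on the saturated chain carbon bound to a carbonyl carbon matters a great deal in this assay: putting 4,4-difluoropiperidin-1-yl in place of the two-ring group gives an 18-fold higher number from compound 1 to compound 3 (1.26 log units; beyond the scatter), a large step beyond the scatter. For the compounds shown here, this is the first pair that differs at this place alone, and it shows that the two groups are far from interchangeable here, with the two-ring group of compound 1 giving much the stronger inhibition. No measurement at hand explains the size of this step.

The change alters several things at once: the five-membered aromatic ring leaves, two fluorines enter, and the count of hydrogen-bond acceptors falls, so the compounds shown cannot say which of these carries the step. A plain piperidin-1-yl group without fluorine, or an imidazol-1-yl group on its own, would help separate these features.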